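Sulfonamide in Place of Nonyl on a Triazole Side Chain

The compounds below may be only part of what the source reports. "The series", "measured", "known", "first", "only" and "open" are said of these compounds alone.

The measured compounds in a functional assay on CFPAC-1 cells (Homo sapiens) for antiproliferative activity, read by MTT assay, with a stated time of 72 h (on this read-out higher numbers stand for weaker inhibition and lower numbers for stronger inhibition), are:
compound 1, `CCCCc1cn(C[C@H](O)[C@H]2OC(=O)C(OCc3ccccc3)=C2OCc2ccccc2)nn1`, giving 73200 nM
compound 2, `O=C1O[C@H]([C@@H](O)Cn2cc(CNS(=O)(=O)c3ccc(F)cc3)nn2)C(OCc2ccccc2)=C1OCc1ccccc1`, giving 34700 nM
compound 3, `CCCCCCCCCCc1cn(C[C@H](O)[C@H]2OC(=O)C(OCc3ccccc3)=C2OCc2ccccc2)nn1`, giving 40300 nM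

Compound 3 sits close to both of its neighbours: its distance from compound 2 is a 1.2-fold higher number from compound 2 to compound 3 (0.06 log units; within the scatter), and its distance from compound 1 is a 1.8-fold lower number from compound 1 to compound 3 (0.26 log units; within the scatter), so on these numbers it is not separated from either.

The unmeasured compound 4, `O=C1O[C@H]([C@@H](O)Cn2cc(CNS(=O)(=O)c3ccc(Cl)cc3)nn2)C(OCc2ccccc2)=C1OCc1ccccc1`, differs from compound 3 in one place: ((4-chlorophenyl)sulfonyl)amino in place of nonyl on a saturated chain carbon bound to an aromatic carbon.

Among the compounds with values here, one measured step bears directly on this change. The step of a 1.2-fold higher number from compound 2 to compound 3 (0.06 log units; within the scatter) is the reverse of the same swap, with the fluoro rather than the chloro sulfonamide, and it did not leave the scatter. The step of a 2.1-fold lower number from compound 1 to compound 2 (0.32 log units; beyond the scatter) shows a modest gain when the fluoro sulfonamide replaced a short alkyl chain. Compound 4 is therefore expected to land near compound 2, with a step of a 1.2-fold lower number from compound 3 to compound 4 (0.09 log units; within the scatter) that is not clearly beyond the scatter. The estimate for compound 4 in this assay is 33000 nM, with a range from 15000 nM to 70000 nM.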

Compound 4, half-maximal inhibitory concentration: 38900 nM
Compound 4: the middle estimate sits 1.2-fold (0.07 log units) below what was measured, within the range that was stated.
By their numbers in this assay, from the lowest: compounds 2, 4, 3 and 1 (each within the scatter of the next, the first and the last beyond it).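

In this assay, ((4-chlorophenyl)sulfonyl)amino in place of nonyl gave a 1.0-fold lower number from compound 3 to compound 4 (0.02 log units; within the scatter), which adds a second sulfonamide to the comparison with the alkyl chain, and again the two kinds of group are not separated on a saturated chain carbon bound to an aromatic carbon. Within the data shown here, the result also gives the first reading on the aromatic ring of the sulfonamide: chloro in place of fluoro on an aromatic carbon gave a 1.1-fold higher number from compound 2 to compound 4 (0.05 log units; within the scatter), so the two halogens cannot be told apart here. Against the butyl compound, the chloro sulfonamide gave a 1.9-fold lower number from compound 1 to compound 4 (0.27 log units; within the scatter), while the fluoro sulfonamide gave a 2.1-fold lower number from compound 1 to compound 2 (0.32 log units; beyond the scatter), so the modest gain seen with fluoro beyond the scatter is not confirmed with chloro, and that gain rests on a narrow margin.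

Nothing available here explains any of these steps. As far as these compounds go, it remains open whether a carboxylic acid or an amine in place of chloro on that aromatic carbon, or a chain longer than nonyl on the saturated chain carbon, would move the number clearly beyond the scatter.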